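A few compounds are considered here, and "the series" means these few. Any claim that something is new, unique, unknown or untested is made for them only; others in the source may bear on it.

Working notes on the series in an assay on isolated protein (strain Charles River) for antagonist activity at histamine H2 receptor (Rattus norvegicus); on this read-out lower numbers stand for an effect already at smaller amounts and higher numbers for an effect only at larger amounts of compound.

Two compounds of the series carry measurements. Compound 1 `Cc1cc(C)c2ccc(=O)n(CCN(C)C)c2n1` gives 3.93 ug/mL in this assay. Compound 2 `Cc1cc(C)c2ccc(=O)n(CCN)c2n1` gives 33.8 ug/mL in this assay, the highest of the two numbers; its nearest neighbour is compound 1, and the step of an 8.6-fold higher number from compound 1 to compound 2 (0.93 log units; beyond the scatter) separates them, with amino in place of dimethylamino on a saturated chain carbon, two bonds along the chain from an aromatic nitrogen.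

Compound 3 `CNCCn1c(=O)ccc2c(C)cc(C)nc21` is not yet measured. It differs from compound 2 by methyl in place of hydrogen on an amine nitrogen, which is methyl in place of hydrogen on an amine nitrogen, so that the amino group of compound 2 becomes methylamino.

Among the measured compounds shown here, the only measured step that bears on this change is an 8.6-fold higher number from compound 1 to compound 2 (0.93 log units; beyond the scatter), which went from dimethylamino to amino. Compound 3 sits between those two end points, with one methyl on the amine nitrogen, so a step back toward the number of compound 1 is expected, smaller than that step but beyond the scatter. For compound 3 the estimate in this assay is 12 ug/mL, with a range of 5 ug/mL to 30 ug/mL, corresponding to an expected step of a 2.8-fold lower number from compound 2 to compound 3 (0.45 log units; beyond the scatter).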

Compound 3, half-maximal effective concentration: 21.1 ug/mL
Estimate against measurement, compound 3: 1.8-fold (0.25 log units) below; the measured number falls inside the stated range.
By their numbers in this assay, from the lowest: compound 1; then compounds 3 and 2 (each within the scatter of the next).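

In this assay, a single methyl on the amine nitrogen gives a 1.6-fold lower number from compound 2 to compound 3 (0.20 log units; within the scatter) and so does not separate methylamino from amino on this chain. Compound 3 remains apart from compound 1, with a 5.4-fold higher number from compound 1 to compound 3 (0.73 log units; beyond the scatter) for hydrogen in place of methyl on the amine nitrogen; among these three compounds, only the dimethylamino compound stands apart beyond the scatter, and the earlier single step could not show that the first methyl on this nitrogen leaves no readable difference while the pair of methyls does. No measured evidence accounts for this difference between methylamino and dimethylamino.

Still open, going by these compounds, is whether the lower number of compound 1 is tied to dimethylamino itself or would also be seen with diethylamino or with the nitrogen held in a pyrrolidine or piperidine ring. The compounds shown also leave open how a longer chain between the core and the amine, such as 3-(dimethylamino)propyl in place of 2-(dimethylamino)ethyl, would read on this assay.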